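This account rests on a few compounds, and the source may have more. Where it says the series, first, only, none or still open, it means among the compounds named here.

Among the compounds with values here, compound 1 `COc1cc2c(Oc3ccc(NC(=O)C4(c5nnc(-c6ccc(F)cc6)o5)CC4)cc3F)ccnc2cc1OCCCN1CCCC1` gives 2340 nM in a functional assay on PC-3 cells (Homo sapiens) for antiproliferative activity, read by MTT assay, with a stated time of 72 h (on this read-out higher numbers stand for weaker inhibition and lower numbers for stronger inhibition), the second highest of the three numbers measured so far. Compound 3 `COc1cc2c(Oc3ccc(NC(=O)c4ncc(-c5ccc(F)cc5)o4)cc3)ccnc2cc1OCCCN1CCC(C)CC1` gives 720 nM in this assay, and compound 2 `COc1cc2nccc(Oc3ccc(NC(=O)c4ncc(-c5ccc(F)cc5)o4)cc3)c2cc1OC` gives 21900 nM in this assay. Within the data shown here, the only single-change step among the measured compounds is a 30-fold lower number from compound 2 to compound 3 (1.48 log units; beyond the scatter); it concerns adding a whole chain where there was none, not the ring at its far end, so it gives little guidance for the change considered here. Compound 4 `COc1cc2c(Oc3ccc(NC(=O)C4(c5nnc(-c6ccc(F)cc6)o5)CC4)cc3F)ccnc2cc1OCCCN1CCCCC1` differs from compound 1 by piperidin-1-yl in place of pyrrolidin-1-yl on a saturated chain carbon, three bonds along the chain from an oxygen on an aromatic ring. Among the measured compounds shown here, no measured pair shows this exchange, so the expected step is none beyond the scatter, namely a 1.2-fold lower number from compound 1 to compound 4 (0.07 log units; within the scatter). Compound 4 is therefore estimated to give about 2000 nM in this assay, with a range from 800 nM to 5000 nM.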

Compound 4, half-maximal inhibitory concentration: 590 nM
Compound 4: the middle estimate sits 3.4-fold (0.53 log units) above what was measured; the whole stated range lies above it.
By their numbers in this assay, from the lowest: compounds 4 and 3 (each within the scatter of the next); then compound 1; then compound 2.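

Putting piperidin-1-yl in place of pyrrolidin-1-yl gives a 4.0-fold lower number from compound 1 to compound 4 (0.60 log units; beyond the scatter) in this assay, so the ring at the far end of the chain matters, not just the presence of the chain. A change confined to that ring is enough to move the number beyond the scatter. Nothing available explains this step.

Still open, going by these compounds, is how morpholin-4-yl or dimethylamino would read at the same chain end, and whether a longer chain would keep the gain. It is also unclear whether this exchange would have the same effect on the core of compound 3.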